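The compounds below may be only part of what the source reports. "The series", "measured", "known", "first", "only" and "open" are said of these compounds alone.

For the measured compounds named here, compound 1 `COC(=O)c1ccc(NCc2cncn2Cc2cccc([N+](=O)[O-])c2)cc1-c1ccccc1` is the first measured compound. In a toxicity assay on NIH3T3 cells (Mus musculus) for cytotoxicity, read by resazurin assay (on this read-out lower numbers stand for an effect already at smaller amounts and higher numbers for an effect only at larger amounts of compound), compound 1 gives > 10000 nM, which is a limit of the assay rather than a number. Compound 2 `Fc1ccc(Cn2cncc2CNc2ccc(-c3nc4ccccc4s3)c(-c3ccccc3)c2)c(F)c1` follows. In this assay compound 2 gives > 1000 nM, again only a limit. Compound 3 `COC(=O)c1ccc(NCc2cncn2Cc2cccc(N)c2)cc1-c1ccccc1` closes the measured set. In this assay compound 3 gives > 10000 nM, a limit once more.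

Compound 3 therefore stands only at a limit, as do the other two values shown: the limit of > 10000 nM in this assay, at which 2 of the 3 values shown sit, and the limit of > 1000 nM in this assay, at which 1 of the 3 values shown sits, describe the whole set. Going by the values given here, the one single-point step, a step that the two limits leave unreadable from compound 1 to compound 3, cannot be read because both ends are limits.

Compound 4 `COC(=O)c1ccc(NCc2cncn2Cc2ccc(F)cc2F)cc1-c1ccccc1` is not yet measured. It differs from compound 3 by 2,4-difluorophenyl in place of 3-aminophenyl on a saturated chain carbon bound to an aromatic nitrogen. Among the compounds with values here, no measured step bears on this change with a readable size, so no direction beyond the scatter can be expected; the three limits only suggest that compound 4 will sit at a limit as well. Compound 4 is accordingly estimated at 20000 nM, within 5000 nM to 100000 nM, an expected step that the limit leaves unreadable from compound 3 to compound 4.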

Compound 4, half-maximal effective concentration: > 1000 nM
Compound 4 was reported as a limit; the forecaster's own chance of this, stated with the estimate: 80%; the middle value does not contradict the limit.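

In this assay compound 4 gives > 1000 nM, which is only a limit. Its steps from compound 1, compound 2 and compound 3 therefore cannot be read, as all four values are limits. The compounds shown leave open at what concentration, if any, each one would reach a half-maximal effect.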